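The source may report more compounds than this note shows. Statements on the series, on what has been measured and on what is new or still open speak of the compounds shown alone.

Measured so far in a functional assay on HT-29 cells (Homo sapiens) for inhibition, read by CellTiter-Glo, with a stated time of 72 h; on this read-out higher numbers stand for lower toxicity in this test and lower numbers for higher toxicity in this test:
- compound 1 `CC1=C(CC(=O)NCCN(C)C)c2cc(F)ccc2/C1=C\c1ccncc1`: 6890 nM
- compound 2 `CC1=C(CC(=O)NCCN2CCCC2)c2cc(F)ccc2/C1=C\c1nc2ccccc2s1`: 1210 nM

Compound 2 has the lower of the two numbers, 1210 nM, which marks it as the more toxic of the pair in this assay, and its gap to compound 1 lies beyond the scatter. The next compound to be measured is compound 3 `CC1=C(CC(=O)NCCN2CCCC2)c2cc(F)ccc2/C1=C\c1ccncc1`. It places pyridin-4-yl in place of 1,3-benzothiazol-2-yl on a double-bonded chain carbon bound to a double-bonded ring carbon of compound 2: pyridin-4-yl in place of 1,3-benzothiazol-2-yl on a double-bonded chain carbon bound to a double-bonded ring carbon.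

Among the measured compounds shown here, no measured pair differs in one place only, so this change has no direct precedent and the expectation remains loose. For the measured compounds named here, the only guide is compound 1, which also carries pyridin-4-yl and gives 6890 nM. A rise in the number beyond the scatter is therefore expected in this assay, pointing to lower toxicity. The expected step is a 3.7-fold higher number from compound 2 to compound 3 (0.57 log units; beyond the scatter). For compound 3 the estimated value is 4500 nM, with an expected range of 1800 nM to 11000 nM.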

Compound 3, half-maximal cytotoxic concentration: 2680 nM
Beside the measured number, compound 3's estimate is 1.7-fold (0.23 log units) above it; measured number inside the range.
By their numbers in this assay, from the lowest: compound 2; then compound 3; then compound 1.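

In this assay, among the compounds shown here, pyridin-4-yl in place of 1,3-benzothiazol-2-yl on a double-bonded chain carbon bound to a double-bonded ring carbon gives a 2.2-fold higher number from compound 2 to compound 3 (0.35 log units; beyond the scatter), the first direct reading of this change, with the pyrrolidin-1-yl chain end held constant and a modest shift towards lower toxicity in this test. The chain end also proves able to move the number on its own: pyrrolidin-1-yl in place of dimethylamino on a saturated chain carbon, two bonds along the chain from an amide-type nitrogen, gives a 2.6-fold lower number from compound 1 to compound 3 (0.41 log units; beyond the scatter), so with pyridin-4-yl held constant this second modest step also lies beyond the scatter. Nothing on hand offers an explanation for either step.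

From the compounds shown here alone, each change rests on a single pair, so whether the pyridin-4-yl step keeps its size with dimethylamino at the chain end remains open. Going by these compounds, how a plain phenyl or a pyridin-3-yl group would read on the double-bonded chain carbon, or a piperidin-1-yl or morpholin-4-yl group at the chain end, also remains open.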